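A few compounds are considered here, and "the series" means these few. Any claim that something is new, unique, unknown or untested is made for them only; others in the source may bear on it.

Three compounds have been measured in a physicochemical assay for solubility, measured as thermodynamic solubility, at pH 7.4; a higher number here means a more soluble compound, a lower number a less soluble compound:
compound 1 `CN1C(=O)C2=C(C1=O)N(CC(=O)Nc1ccc(-c3ccccc3)cn1)CCC2` gives 0.24 ug/mL;
compound 2 `CN1C(=O)C2=C(C1=O)N(CC(=O)Nc1ccc(-c3cccnc3)nc1)CCC2` gives 13 ug/mL;
compound 3 `Cc1ccc(-c2ccc(NC(=O)CN3CCCC4=C3C(=O)N(C3CC3)C4=O)nn2)cn1` gives 11.1 ug/mL.

In this assay compound 2 and compound 3 lie within the usual scatter of one another, so neither can be placed ahead of the other; compound 1 stands far below both, and that gap is beyond the scatter. The unmeasured compound 4 `CN1C(=O)C2=C(C1=O)N(CC(=O)Nc1ccc(-c3ccccc3)nc1)CCC2` is reached from compound 2 by a single change: phenyl in place of pyridin-3-yl on an aromatic carbon. For the measured compounds named here, no measured pair differs in exactly this one place, so the size of the step cannot be read from the data and must be estimated. Going by the values given here, the only guide is compound 1, which also carries a phenyl on its amide-bearing ring and gives 0.24 ug/mL, a far lower number than compound 2. On that basis compound 4 is expected to show a clear loss in this assay, a step of a 13-fold lower number from compound 2 to compound 4 (1.11 log units; beyond the scatter). The estimated value for compound 4 is 1 ug/mL, with a likely range from 0.2 ug/mL to 6 ug/mL.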

Compound 4, solubility: 0.75 ug/mL
Compound 4: middle estimate off by 1.3-fold (0.12 log units), on the high side, and the stated range covers the measured number.
By their numbers in this assay, from the lowest: compound 1; then compound 4; then compounds 3 and 2 (each within the scatter of the next).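

In this assay, for the compounds shown here, replacing pyridin-3-yl with phenyl on an aromatic carbon, next to the ring nitrogen and para to a large group, gives a 17-fold lower number from compound 2 to compound 4 (1.24 log units; beyond the scatter), the first comparison in this set in which only one place differs. The two groups have the same count of heavy atoms, and the change swaps one ring nitrogen for carbon, so on this core a single-atom exchange at this position is enough to produce a step beyond the scatter. Nothing available here accounts for the size of this step.

The compounds shown leave open how a pyridin-4-yl, a pyrimidin-5-yl or a morpholine at this position would compare with the pyridin-3-yl of compound 2. They also leave open whether the same exchange would give a step of similar size on the core of compound 3.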